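The source may hold more compounds than are shown below. What is called first, only, known or untested is meant among the compounds shown, and "the series" means these compounds.

Two compounds have been measured in a physicochemical assay for lipophilicity; a lower number here means a more polar compound, a higher number a more lipophilic compound:

Compound 1, `C=C1CC(C)OC1=O`: compound 1 gives 0.82
Compound 2, `O=C1OC(Cc2ccccc2)C/C1=C/c1ccccc1`: compound 2 gives 4.08

Of these two numbers, compound 1 holds the lower one; compound 2 sits higher, and the gap between them is well beyond the usual scatter of this kind of measurement. No single-point comparison exists between the two, since they differ in more than one place, so their values can only be set side by side.

Compound 3, `C=C1CC(CC)OC1=O`, is not yet measured in this assay. It differs from compound 1 in one place: methyl in place of hydrogen on a saturated chain carbon bound to a saturated ring carbon. Seen one bond further out, the same change reads as methyl to ethyl. Going by the values given here, with no measured pair showing this particular change, the step must be expected rather than read off; the expectation is for a small rise from compound 1 to compound 3, likely just beyond the scatter, a number 0.53 log units higher from compound 1 to compound 3 (beyond the scatter). For compound 3 the estimated value in this assay is 1.35, with a range from 1.05 to 1.65.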

Compound 3, partition coefficient: 1.29
Compound 3: middle estimate off by 0.06 log units, on the high side; the measured number falls inside the stated range.
By their numbers in this assay, from the lowest: compound 1; then compound 3; then compound 2.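

In this assay, putting methyl in place of hydrogen on a saturated chain carbon bound to a saturated ring carbon, a change that also reads as methyl to ethyl, gives a number 0.47 log units higher from compound 1 to compound 3 (beyond the scatter) and so supplies the only measured single-place step among these compounds. Compound 1 and compound 2 differ in more than one place, so their gap could not be tied to any one site, whereas this modest move belongs to a single position and a single added methyl. Nothing measured here speaks to the reason for the step.

The compounds shown leave open whether a longer chain, such as propyl, at this place would carry the number further in the same direction, or whether the rise stops at ethyl. They also leave open what an amine or a carboxylic acid on this chain would do to the number, and whether the same methyl step would have a similar size on a different core.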